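Pyrimidin-2-yl in Place of Pyridin-3-yl on a Ring Amine

A few compounds are considered here, and "the series" means these few. Any claim that something is new, unique, unknown or untested is made for them only; others in the source may bear on it.

compound 1, `Nc1ccccc1NC(=O)c1ccc(CSC(=S)N2CCN(c3cccnc3)CC2)cc1`: 66.2%
compound 2, `Nc1ccccc1NC(=O)c1ccc(CSC(=S)N(Cc2ccccc2)Cc2ccccc2)cc1`: 1%

Of the compounds shown here, two have so far been measured in a functional assay on HeLa cells (Homo sapiens) for antiproliferative activity, read by CCK-8 assay, with a stated time of 72 h, tested at 2 uM; a higher number here means a stronger effect of the compound at the concentration tested, a lower number a weaker effect. Compound 1 `Nc1ccccc1NC(=O)c1ccc(CSC(=S)N2CCN(c3cccnc3)CC2)cc1` gives 66.2% in this assay, the higher of the two numbers. Compound 2 `Nc1ccccc1NC(=O)c1ccc(CSC(=S)N(Cc2ccccc2)Cc2ccccc2)cc1` gives 1% in this assay, a number far below that of compound 1, a gap well beyond the scatter. The two structures differ in several places at once, so the two values alone do not show which part of the change carries the gap.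

Compound 3 `Nc1ccccc1NC(=O)c1ccc(CSC(=S)N2CCN(c3ncccn3)CC2)cc1` has not yet been measured. It differs from compound 1 in one place: pyrimidin-2-yl in place of pyridin-3-yl on an amine nitrogen in a ring. The rest of the structure of compound 1 is kept unchanged. Within the data shown here, with no measured pair of this kind to lean on, the step is expected to be small, pointing slightly downward or staying within the scatter. The step of a number 11.2 percentage points lower from compound 1 to compound 3 (beyond the scatter) is the expectation for compound 3. Compound 3 is expected to give 55% in this assay, within a range from 25% to 80%.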

Compound 3, a percentage reported as inhibition, at one concentration (the size of the read-out at that concentration, not a potency): 52.2%
Estimate against measurement, compound 3: 2.8 percentage points above; the range from low to high includes it.
By their numbers in this assay, from the lowest: compound 2; then compound 3; then compound 1.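

In this assay, among these compounds, the exchange of pyridin-3-yl for pyrimidin-2-yl on an amine nitrogen in a ring is the first change in a single place, and it gives a number 14 percentage points lower from compound 1 to compound 3 (beyond the scatter) as its result. This shows that the read-out responds to the aromatic ring at this position, even though both groups are six-membered aromatic rings and pyrimidin-2-yl differs in carrying two hetero atoms where pyridin-3-yl carries one. It also shows that the effect is reduced rather than lost, with compound 3 at 52.2% at the one concentration tested, and no evidence is available to explain the step.

Going by these compounds, a single exchange cannot separate the number of ring nitrogens from their placement, so it remains open how pyridin-2-yl, pyridin-4-yl or a plain phenyl would read at this position. On these data alone, it is also open whether a non-aromatic group on the same nitrogen, such as methyl or acetyl, would keep the effect, and whether the step of this size would recur on another core.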